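Replacing a Fluorinated Phenol with a Methylphenyl Ring

The source may report more compounds than this note shows. Statements on the series, on what has been measured and on what is new or still open speak of the compounds shown alone.

Compound 3 `O=S(=O)(c1cccc(O)c1)N1CCN(c2ccc(F)c(O)c2)CC1` is tested in an assay on microsomes from placenta for inhibition of 17-beta-hydroxysteroid dehydrogenase type 2 (Homo sapiens), read by HPLC, with a stated time of 20 min, tested at 1 uM (on this read-out lower numbers stand for less inhibition and higher numbers for more inhibition at the one concentration tested (going by the name of the read-out)), and gives 48%. Among the three compounds measured so far, that number stands second highest. Its nearest neighbour is compound 1 `O=S(=O)(c1cccc(O)c1)N1CCN(c2cccc(O)c2)CC1`, which in this assay gives 25%. The furthest is compound 2 `COc1cccc(N(C)C(=O)c2ccc(-c3ccc(C)c(C)c3)cc2)c1`, which in this assay gives 75%. Compound 1 and compound 3 share the same core and differ in one place only: the step of a number 23 percentage points higher from compound 1 to compound 3 (beyond the scatter), a fluoro in place of hydrogen on an aromatic carbon, lies beyond the scatter and is modest in size.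

Compound 4 `Cc1cccc(N2CCN(S(=O)(=O)c3cccc(O)c3)CC2)c1` has not yet been measured. It differs from compound 3 in one place: 3-methylphenyl in place of 4-fluoro-3-hydroxyphenyl on an amine nitrogen in a ring. The ring that carried a hydroxyl and a fluorine is thus exchanged for a ring carrying only a methyl group. Within the data shown here, no measured step covers this exchange directly. Compound 2 rests on a different core, so its number says little here. Among the measured compounds shown here, the only guide is that the fluorine which raised the number in the step from compound 1 to compound 3 is now removed, together with the hydroxyl, so a fall beyond the scatter is expected rather than a rise.

For compound 4 in this assay the expected value is 30%, with a range from 8% to 58%. This estimate amounts to an expected step of a number 18 percentage points lower from compound 3 to compound 4 (beyond the scatter).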

Compound 4, a percentage reported as inhibition, at one concentration (the size of the read-out at that concentration, not a potency): 27%
For compound 4 the middle estimate is 3 percentage points above the measured one; measured number inside the range.
By their numbers in this assay, from the lowest: compounds 1 and 4 (each within the scatter of the next); then compound 3; then compound 2.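

In this assay, a number 21 percentage points lower from compound 3 to compound 4 (beyond the scatter) shows that the change from 4-fluoro-3-hydroxyphenyl to 3-methylphenyl on the amine nitrogen in a ring moves the number by a modest amount, and the other step puts that drop in context. With methyl in place of hydroxy on an aromatic carbon, a number 2 percentage points higher from compound 1 to compound 4 (within the scatter) shows that, without the fluoro, these two groups cannot be told apart here, even though 3-methylphenyl has 0 hydrogen-bond donors and 0 hydrogen-bond acceptors. Among the compounds with this core, the one carrying the fluoro therefore stands apart from the other two, although no data shown here explain why the number changes.

From the compounds shown here alone, it remains open whether a fluoro added to the 3-methylphenyl ring would raise the number as it did on the ring carrying the hydroxy group. Going by these compounds, how an amine, a carboxylic acid or a longer chain such as ethyl in place of the methyl would read in this assay also remains open.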